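Cyclobutylamino to allylamino: a first step in rat aorta

The compounds below may be only part of what the source reports. "The series", "measured", "known", "first", "only" and "open" are said of these compounds alone.

For the measured compounds named here, compound 2 `O=S1(=O)NC(NC2CCC2)=Nc2ccc(Br)cc21` holds the only true number so far in this small series. In a functional assay (aorta) with Rattus norvegicus as the target (a lower number here means that less compound is needed, a higher number that more compound is needed for the effect), compound 2 gives 21.7 uM. Compound 1 `C=CCNC1=Nc2ccc(F)cc2S(=O)(=O)N1` gives > 300 uM, which is a limit of the assay and not a number.

The next compound to be read is compound 3 `C=CCNC1=Nc2ccc(Br)cc2S(=O)(=O)N1`. Its difference from compound 2 is allyl in place of cyclobutyl on an amine nitrogen. The one-carbon-shorter count and the loss of the four-membered ring are the whole of the change, and the shared core stays as it is.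

Going by the values given here, no measured step covers this change, so the expectation rests on the single number of compound 2, 21.7 uM, and on the swap itself. A modest shift is expected in this assay, towards more compound being needed, and it may not clear the usual scatter. The expected size is a 1.8-fold higher number from compound 2 to compound 3 (0.27 log units; within the scatter). For compound 3 the estimated value is 40 uM. The expected range runs from 12 uM to 180 uM, and it is kept wide on the weak side.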

Compound 3, concentration for half-maximal effect: 3 uM
Estimate against measurement, compound 3: 13-fold (1.12 log units) above; measured number below the stated range.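

With bromo held fixed, allyl in place of cyclobutyl on the amine nitrogen gives in this assay a 7.2-fold lower number from compound 2 to compound 3 (0.86 log units; beyond the scatter) and so shows that the four-membered ring is not required for the effect at this place, with the open allyl chain reading better than the ring. With allylamino held fixed, bromo in place of fluoro on the aromatic carbon gives an at least 100-fold lower number from compound 1 to compound 3 (2.00 log units; beyond the scatter) and so shows that the series also responds to a change at this second place, a point that compound 2 alone could not show. The size of that step is only a bound, as compound 1 stands at a limit of the assay and not at a number: the limit of > 300 uM in this assay, at which 1 of the 3 values shown sits.

As far as these compounds go, it remains open whether the gain at the amine nitrogen belongs to the double bond of allyl or simply to the open chain, and a saturated propyl group at the same place would separate the two readings. From the compounds shown here alone, it also remains open how far the halogen step really reaches and whether the allyl step holds with fluoro in place of bromo, and chloro on the same aromatic carbon would add a true number to that comparison.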